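The compounds below may be only part of what the source reports. "The series", "measured", "known", "first", "only" and "open" are said of these compounds alone.

Measured compounds:

Compound 1, `CCOC(=O)c1sc(/N=C2\NC(=O)/C(=C3/C(=O)N(Cc4ccccc4)c4ccc(Cl)cc43)S2)nc1C`, gives 52.1 ug/mL in an ADME assay on WI-38 cells (Homo sapiens) for cytotoxicity, read by MTT assay; on this read-out higher numbers stand for weaker inhibition and lower numbers for stronger inhibition.
Compound 2, `CC(=O)c1sc(/N=C2\NC(=O)/C(=C3/C(=O)N(C)c4ccc(Cl)cc43)S2)nc1C`, gives 19.5 ug/mL in this assay.

Of the two numbers recorded so far, compound 2 holds the lower one, and its gap to compound 1 lies beyond the usual scatter of repeated measurements, so compound 2 counts as the stronger inhibitor of the pair in this assay. Among the compounds with values here, compound 1 and compound 2 differ at more than one place, so no single step between them can be isolated.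

Compound 3, `CC(=O)c1sc(/N=C2\NC(=O)/C(=C3/C(=O)N(C)c4ccccc43)S2)nc1C`, has not yet been measured. It differs from compound 2 in one place only: hydrogen in place of chloro on an aromatic carbon. Within the data shown here, no measured pair in this set isolates such a change, so the direction of the step rests on the change itself rather than on a comparable example. Compound 3 is expected to give a somewhat higher number than compound 2, with a step of a 1.4-fold higher number from compound 2 to compound 3 (0.16 log units; within the scatter), modest in size and close to the edge of the scatter. On that basis, compound 3 is estimated at 28 ug/mL in this assay, within a range from 13 ug/mL to 60 ug/mL.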

Compound 3, half-maximal inhibitory concentration: 5.3 ug/mL
Compound 3: the middle estimate sits 5.3-fold (0.72 log units) above what was measured; the measured number lies below the stated range.
By their numbers in this assay, from the lowest: compound 3; then compound 2; then compound 1.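

Within the data shown here, compound 2 and compound 3 form the only pair here that isolates a single change, so the effect of this position can now be read directly: in this assay, hydrogen in place of chloro gives a 3.7-fold lower number from compound 2 to compound 3 (0.57 log units; beyond the scatter), a step beyond the scatter and towards stronger inhibition. The chloro on this aromatic carbon, meta to a fused ring and para to a fused ring, is therefore not a silent feature of the series, since removing it alone shifts the cytotoxicity read-out on these cells by a clear margin. Nothing in the material shown accounts for the size or direction of this step.

Going by these compounds, this single pair compares only hydrogen and chloro, so it remains open how another group at this aromatic carbon, such as fluoro, methoxy or an amine, would read in this assay. On these data alone, it also remains open whether the same change would produce a step of similar direction and size in compound 1, which carries the same chloro but differs elsewhere.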